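The compounds below may be only part of what the source reports. "The series", "measured", "known", "first", "only" and "open" are said of these compounds alone.

Compound 2 `Cc1nc(C)n(CC(=O)N2CCN(c3sc(C(F)(F)F)nc3-c3cnc(C(C)(C)C)nc3)C[C@H]2C)n1` carries a 2-(tert-butyl)pyrimidin-5-yl group on the shared core, and in a functional assay on U2OS cells for antagonist activity at C-X-C chemokine receptor type 3 (Homo sapiens), read by beta-arrestin recruitment (on this read-out lower numbers stand for stronger inhibition and higher numbers for weaker inhibition), compound 2 gives 1030 nM. For the measured compounds named here, of the two compounds measured so far, compound 2 has the highest number. Its nearest neighbour is compound 1 `CCOc1ncc(-c2nc(C(F)(F)F)sc2N2CCN(C(=O)Cn3nc(C)nc3C)[C@H](C)C2)cn1`, in which an ethoxy group stands where compound 2 has the tert-butyl; in this assay compound 1 gives 173 nM. Going by the values given here, the single measured step, a 6.0-fold higher number from compound 1 to compound 2 (0.77 log units; beyond the scatter), lies beyond the scatter and runs toward weaker inhibition.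

Compound 3 `COc1ccc(-c2nc(C(F)(F)F)sc2N2CCN(C(=O)Cn3nc(C)nc3C)[C@H](C)C2)cn1` has not yet been measured. It differs from compound 2 in one place: 6-methoxypyridin-3-yl in place of 2-(tert-butyl)pyrimidin-5-yl on an aromatic carbon. Among the compounds with values here, the only step that bears on this change is a 6.0-fold higher number from compound 1 to compound 2 (0.77 log units; beyond the scatter), which went from a ring bearing an ethoxy group to one bearing a tert-butyl group; compound 3 returns to a ring bearing a methoxy group. Within the data shown here, no measured pair sets a 6-methoxypyridin-3-yl against a pyrimidin-5-yl, or methoxy against ethoxy, so the size is uncertain. The step expected is a 4.1-fold lower number from compound 2 to compound 3 (0.61 log units; beyond the scatter). The estimate for compound 3 in this assay is 250 nM, with a range from 80 nM to 800 nM.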

Compound 3, half-maximal inhibitory concentration: 1170 nM
For compound 3 the middle estimate is 4.7-fold (0.67 log units) below the measured one, and the stated range ends below it.
By their numbers in this assay, from the lowest: compound 1; then compounds 2 and 3 (each within the scatter of the next).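

In this assay, replacing the 2-(tert-butyl)pyrimidin-5-yl group with 6-methoxypyridin-3-yl gives a 1.1-fold higher number from compound 2 to compound 3 (0.06 log units; within the scatter), so an alkoxy group on the aromatic ring at this position does not by itself bring the number back toward that of compound 1. Compound 1, at 173 nM, now stands apart from both other compounds, with a 6.8-fold higher number from compound 1 to compound 3 (0.83 log units; beyond the scatter) added to the earlier tert-butyl step, and two quite different groups at this position give numbers within the scatter of each other, so the advantage seen so far belongs to the 2-ethoxypyrimidin-5-yl group alone. Nothing measured here explains why these groups rank as they do.

Compound 1 and compound 3 differ in both the ring and its alkoxy chain, so the step between them cannot say which of the two matters more. As far as these compounds go, a 2-methoxypyrimidin-5-yl or a 6-ethoxypyridin-3-yl group would separate those two changes, and whether a longer chain such as propoxy would go further in the direction of compound 1 remains open.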